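Swapping the aryl group on a shared core: permeability outlook

The compounds below may be only part of what the source reports. "The series", "measured", "known", "first", "only" and "open" are said of these compounds alone.

This short series shares one core, a five-membered aromatic ring with one nitrogen and one oxygen, carrying a methyl group, a large side chain and an aryl group. Compound 1 `Cc1oc(-c2c(C)c(C)c(C)c(C)c2C)nc1CN1CCC(C(=O)NCCCN2C[C@H](C)C[C@H](C)C2)CC1` has been tested in a physicochemical assay for permeability, using PAMPA (on this read-out higher numbers stand for higher permeability and lower numbers for lower permeability), and gives 455 10^-6 cm/s. Among the compounds with values here, that is the only number in the set: compound 2 `Cc1cccc(Cl)c1-c1nc(CN2CCC(C(=O)NCCCN3CCC(C(C)C)CC3)CC2)c(C)o1` was also prepared, but in this assay compound 2 gives "not determined" (no result reported), so nothing can be said of how it compares. Compound 1 therefore stands alone as the single measured point.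

Compound 3 `COc1cccc(Br)c1-c1nc(CN2CCC(C(=O)NCCCN3C[C@H](C)C[C@H](C)C3)CC2)c(C)o1` has not yet been measured. Compared with compound 1 it differs in one place: 2-bromo-6-methoxyphenyl in place of 2,3,4,5,6-pentamethylphenyl on an aromatic carbon. Within the data shown here, no step between two measured compounds is available to show how a change of this kind shifts the read-out. With only the value of compound 1 as a footing, compound 3 is expected to land close to it, with a step of a 1.3-fold lower number from compound 1 to compound 3 (0.11 log units; within the scatter) that may stay within the usual scatter or drift modestly downward. The estimate for compound 3 is 350 10^-6 cm/s, with a likely range from 170 10^-6 cm/s to 650 10^-6 cm/s.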

Compound 3, apparent permeability: 245 10^-6 cm/s
Beside the measured number, compound 3's estimate is 1.4-fold (0.15 log units) above it, within the range that was stated.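

At the aryl position of the shared core, there is now a step to read in this assay: the change to 2-bromo-6-methoxyphenyl gives a 1.9-fold lower number from compound 1 to compound 3 (0.27 log units; within the scatter) and so stays inside the spread expected from repeated measurements. This position can therefore take a ring carrying one bromine and one methoxy group in place of a ring carrying five methyl groups, a swap of 11 heavy atoms for 9 that also brings in a hydrogen-bond acceptor, with no difference in the read-out that stands clear of the scatter. Nothing shown here accounts for this outcome or ties it to any feature of either group.

The bromine and the methoxy group enter together, so this single step cannot show what either would do alone. It also leaves open how the read-out would respond to an aryl ring carrying an amine or a carboxylic acid at this position, groups that differ far more from pentamethylphenyl than this swap does.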